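Aryl replacement on the core carbon: clearance notes

A few compounds are considered here, and "the series" means these few. Any claim that something is new, unique, unknown or untested is made for them only; others in the source may bear on it.

In an ADME assay (liver) for metabolic stability, with Liver microsome (Rattus norvegicus) as the target, using microsomes and NADPH, with a stated time of 30 min, tested at 1 uM (on this read-out lower numbers stand for slow clearance and higher numbers for fast clearance), compound 2 `Nc1ccc(S(=O)(=O)N2CCN(c3ncc(C(O)(C(F)(F)F)C(F)(F)F)cc3C#CC3CC3)CC2)cn1` gives 67 mL.min-1.g-1. Within the data shown here, it stands second highest of the three measured members: compound 1 `Nc1ccc(S(=O)(=O)N2CCN(c3ncc(C(O)(C(F)(F)F)C(F)(F)F)cc3C3CC3)CC2)cn1` gives 27 mL.min-1.g-1 and compound 3 `CC(C)n1cc(-c2cc(C(O)(C(F)(F)F)C(F)(F)F)cnc2N2CCN(S(=O)(=O)c3ccc(N)nc3)CC2)cn1` gives 198 mL.min-1.g-1. The measured steps are a 2.5-fold higher number from compound 1 to compound 2 (0.39 log units; beyond the scatter), a 3.0-fold higher number from compound 2 to compound 3 (0.47 log units; beyond the scatter) and a 7.3-fold higher number from compound 1 to compound 3 (0.87 log units; beyond the scatter), each beyond the scatter and each upward from the cyclopropyl member.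

Compound 4 `Nc1ccc(S(=O)(=O)N2CCN(c3ncc(C(O)(C(F)(F)F)C(F)(F)F)cc3-c3ccncc3)CC2)cn1` differs from compound 2 by pyridin-4-yl in place of 2-cyclopropylethynyl on an aromatic carbon. The step that bears most directly on this change is a 3.0-fold higher number from compound 2 to compound 3 (0.47 log units; beyond the scatter), where an aromatic ring likewise took the place of the 2-cyclopropylethynyl group; the ring entering there was 1-isopropyl-1H-pyrazol-4-yl, whereas here it is pyridin-4-yl. The step of a 7.3-fold higher number from compound 1 to compound 3 (0.87 log units; beyond the scatter) also places an aromatic ring at this carbon well above the cyclopropyl member. A step upward from compound 2 to compound 4 is therefore expected, of about a 1.4-fold higher number from compound 2 to compound 4 (0.15 log units; within the scatter), short of the step seen with the isopropyl-bearing ring. Compound 4 is expected to give about 95 mL.min-1.g-1, with a range of 45 mL.min-1.g-1 to 200 mL.min-1.g-1.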

Compound 4, intrinsic clearance in microsomes: 31 mL.min-1.g-1
Estimate against measurement, compound 4: 3.1-fold (0.49 log units) above; the measured number lies below the stated range.
By their numbers in this assay, from the lowest: compounds 1 and 4 (each within the scatter of the next); then compound 2; then compound 3.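

In this assay the exchange of 2-cyclopropylethynyl for pyridin-4-yl brings a 2.2-fold lower number from compound 2 to compound 4 (0.33 log units; beyond the scatter) and the exchange of 1-isopropyl-1H-pyrazol-4-yl for pyridin-4-yl brings a 6.4-fold lower number from compound 3 to compound 4 (0.81 log units; beyond the scatter) on the same read-out, so an aromatic ring on this carbon does not by itself go with fast clearance. Cyclopropyl and pyridin-4-yl cannot be told apart here, with a 1.1-fold higher number from compound 1 to compound 4 (0.06 log units; within the scatter) for the exchange, although one is a three-membered ring of carbon only and the other a six-membered aromatic ring with a nitrogen. Nothing measured in this series accounts for the gap between the two aromatic rings.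

From the compounds shown here alone, whether the high number of compound 3 goes with its isopropyl group or with the ring carrying it stays open. Also open, going by these compounds, is how a phenyl ring, a pyridin-3-yl ring or a pyridin-4-yl ring bearing an amine would read on this carbon.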